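Thiazolyl in Place of Methoxyphenyl on the Shared Core

The source may report more compounds than this note shows. Statements on the series, on what has been measured and on what is new or still open speak of the compounds shown alone.

Compound 1 `COC1=C(C)C(=O)/C(=C(O)/C=C/c2ccc(OC)cc2)C(=O)C1(C)C` carries a 4-methoxyphenyl on the chain that leaves the shared core. Going by the values given here, in a functional assay on A-431 cells (Homo sapiens) for cytotoxicity (on this read-out lower numbers stand for an effect already at smaller amounts and higher numbers for an effect only at larger amounts of compound), compound 1 gives 9.2 ug/mL, the upper of the two numbers measured so far, though its only neighbour lies within the scatter. That neighbour is compound 2 `COC1=C(C)C(=O)/C(=C(O)/C=C/c2ccccc2OC)C(=O)C1(C)C`, which in this assay gives 6.6 ug/mL; the step of a 1.4-fold lower number from compound 1 to compound 2 (0.14 log units; within the scatter), a 2-methoxyphenyl in place of 4-methoxyphenyl, does not exceed the scatter. Compound 3 `COC1=C(C)C(=O)/C(=C(O)/C=C/c2nccs2)C(=O)C1(C)C` has not yet been measured. It differs from compound 1 as follows: 1,3-thiazol-2-yl in place of 4-methoxyphenyl on a double-bonded chain carbon bound to a double-bonded chain carbon. Among the compounds with values here, no measured step exchanges the aromatic ring itself, and the single step known keeps the phenyl and stays within the scatter, so it bears on this change only loosely. The step of a 1.2-fold higher number from compound 1 to compound 3 (0.08 log units; within the scatter) is therefore expected to be modest. Compound 3 is estimated at 11 ug/mL, within a range from 4 ug/mL to 30 ug/mL.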

Compound 3, concentration for half-maximal effect: 6 ug/mL
Compound 3: middle estimate off by 1.8-fold (0.26 log units), on the high side; measured number inside the range.
By their numbers in this assay, from the lowest: compounds 3, 2 and 1 (each within the scatter of the next).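

The result shows that the aromatic ring itself can be exchanged at this place, on a double-bonded chain carbon bound to a double-bonded chain carbon, and not only the position of the methoxy group on the phenyl. In this assay, 1,3-thiazol-2-yl in place of either methoxyphenyl gives no step beyond the scatter (a 1.5-fold lower number from compound 1 to compound 3 (0.19 log units; within the scatter); a 1.1-fold lower number from compound 2 to compound 3 (0.04 log units; within the scatter)), even though a five-membered aromatic ring with 2 hetero atoms replaces a six-membered aromatic ring of carbon only. Nothing available accounts for this flat picture.

The three compounds leave open whether any group at this place can move the number beyond the scatter. A phenyl bearing an amine or a carboxylic acid, or a saturated piperidine ring in place of the aromatic ring, would test this.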